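The source may hold more compounds than are shown below. What is called first, only, known or untested is meant among the compounds shown, and "the series" means these compounds.

Working notes on the series.

Compound 3 `NC(c1ccccc1)C1CCN(c2ncnc3[nH]ccc23)CC1` gives 246 nM in an assay on isolated protein for inhibition of RAC-beta serine/threonine-protein kinase (Homo sapiens), read by radiometric assay and filter binding (a higher number here means a weaker inhibitor, a lower number a stronger inhibitor), the second highest number of the three measured, between compound 1 `NCC1CCN(c2ncnc3[nH]ccc23)CC1` with 770 nM and compound 2 `NC(c1ccc(Cl)cc1)C1CCN(c2ccnc3[nH]ccc23)CC1` with 12 nM. Within the data shown here, the one step measured in a single place, a 3.1-fold lower number from compound 1 to compound 3 (0.50 log units; beyond the scatter), comes from the phenyl group entering on the saturated chain carbon bound to the amine nitrogen and the saturated ring carbon.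

Compound 4 `NC(c1ccc(Cl)cc1)C1CCN(c2ncnc3[nH]ccc23)CC1` takes the change chloro in place of hydrogen on an aromatic carbon relative to compound 3, the phenyl becoming 4-chlorophenyl. Among the measured compounds shown here, no measured step isolates this change: compound 2 carries the same 4-chlorophenyl but also a different core from compound 3, so its number and that of compound 3 differ in two places at once and only show that the chlorinated analogue on the other core sits low. Without a direct comparison the expectation for compound 4 rests on that single pair and is held loose: a modest step downward, a 2.7-fold lower number from compound 3 to compound 4 (0.44 log units; beyond the scatter), is expected, giving an estimated 90 nM for compound 4 in this assay, with a range from 25 nM to 320 nM.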

Compound 4, half-maximal inhibitory concentration: 25 nM
For compound 4 the middle estimate is 3.6-fold (0.56 log units) above the measured one; low and high end bracket the measured number.
By their numbers in this assay, from the lowest: compound 2; then compound 4; then compound 3; then compound 1.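

In this assay, chloro in place of hydrogen on the aromatic carbon, para to a large group, gives a 9.8-fold lower number from compound 3 to compound 4 (0.99 log units; beyond the scatter), so a single added atom on the phenyl ring now has a directly measured effect on the shared core. Taken together with the earlier 3.1-fold lower number from compound 1 to compound 3 (0.50 log units; beyond the scatter) for phenyl alone, this means that 4-chlorophenyl in place of hydrogen on the chain carbon gives a 31-fold lower number from compound 1 to compound 4 (1.49 log units; beyond the scatter), the first step in the series rated large. Nothing available bears on the origin of the chloro step.

Whether chloro is special at this place remains open, since the compounds shown include no fluoro, bromo, methyl, methoxy or trifluoromethyl there. They also leave open how chloro would act with the amine replaced by an amide.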